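Pyrazolyl Replaces Phenyl on a Tetrahydroquinoline Amide

A few compounds are considered here, and "the series" means these few. Any claim that something is new, unique, unknown or untested is made for them only; others in the source may bear on it.

Measured so far:
compound 1 `CNC(=O)N1CCCc2ccc(NC(=O)c3ccc(-c4cc[nH]n4)cc3)cc21`: 99.1%
compound 2 `CNC(=O)N1CCCc2ccc(NC(=O)c3cccc(-c4ccccc4)c3)cc21`: 1.39%
compound 3 `CNC(=O)N1CCCc2ccc(NC(=O)c3ccc(-c4ccn(C)n4)cc3)cc21`: 97%

In a functional assay on MV4-11 cells (Homo sapiens) for antiproliferative activity, with a stated time of 6 days, tested at 6.25 uM (a lower number here means a weaker effect, a higher number a stronger effect of the compound at the concentration tested), compound 2 stands lowest of the three, far beyond the scatter from compound 3 and from compound 1. Compound 4 `CNC(=O)N1CCCc2ccc(NC(=O)c3cccc(-c4cnn(S(C)(=O)=O)c4)c3)cc21` differs from compound 2 by 1-(methylsulfonyl)-1H-pyrazol-4-yl in place of phenyl on an aromatic carbon. Going by the values given here, the one measured step, a number 2.1 percentage points lower from compound 1 to compound 3 (within the scatter), concerns only a change on a pyrazole nitrogen and does not bridge the change from phenyl to pyrazolyl; no step covers that. Both carry pyrazolyl groups on the shared core: compound 1 gives 99.1% and compound 3 gives 97%, so a pyrazolyl group can go with a strong effect. Compound 4 is therefore expected to rise, a number 38.6 percentage points higher from compound 2 to compound 4 (beyond the scatter), but with wide uncertainty. Compound 4 is estimated at 40%, between 3% and 92%.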

Compound 4, a percentage reported as inhibition, at one concentration (the size of the read-out at that concentration, not a potency): 18%
Beside the measured number, compound 4's estimate is 22 percentage points above it; the measured number falls inside the stated range.
By their numbers in this assay, from the lowest: compound 2; then compound 4; then compounds 3 and 1 (each within the scatter of the next).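

In this assay, going by these compounds alone, the exchange of phenyl for 1-(methylsulfonyl)-1H-pyrazol-4-yl, on an aromatic carbon meta to a large group, gives a number 16.6 percentage points higher from compound 2 to compound 4 (beyond the scatter) and is the first measured step across this change. It shows that this place responds to the new group, though only modestly. No evidence is at hand on what lies behind the size of this step.

As far as these compounds go, whether the gain belongs to the pyrazole ring or to the methylsulfonyl group on its nitrogen stays open. So does the outcome of an amine or a carboxylic acid at this same place.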